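The source may report more compounds than this note shows. Statements on the series, on what has been measured and on what is new or still open speak of the compounds shown alone.

Among the measured compounds shown here, compound 2 `Nc1nn(C(=O)Nc2ccc(Cc3ccccc3)cc2)c2ccc(Cl)cc12` gives 217 nM in a functional assay on CAKI-1 cells (Homo sapiens) for antiproliferative activity, read by sulforhodamine B assay, with a stated time of 48 h (on this read-out lower numbers stand for stronger inhibition of growth and higher numbers for weaker inhibition of growth), the lowest of the two numbers measured so far. For the measured compounds named here, its only measured neighbour is compound 1 `Nc1nn(C(=O)Nc2ccc(Cc3ccccc3)cc2)c2ccccc12`, which in this assay gives 21100 nM; the step of a 97-fold lower number from compound 1 to compound 2 (1.99 log units; beyond the scatter) shows how much the chloro group on the shared core matters for this read-out. Compound 3 `Nc1ccc2c(c1)c(N)nn2C(=O)Nc1ccc(Cc2ccccc2)cc1` has not yet been measured. It differs from compound 2 by amino in place of chloro on an aromatic carbon. Going by the values given here, the one measured step that bears on this place is a 97-fold lower number from compound 1 to compound 2 (1.99 log units; beyond the scatter), a large gain on going from hydrogen to chloro; nothing measured shows what an amino group does there. Compound 3 is therefore expected to land somewhere between its two neighbours, with a step of about a 14-fold higher number from compound 2 to compound 3 (1.14 log units; beyond the scatter), though the size is uncertain. The estimate for compound 3 in this assay is 3000 nM, within a range from 400 nM to 20000 nM.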

Compound 3, concentration for 50% growth inhibition: 4300 nM
Compound 3: middle estimate off by 1.4-fold (0.16 log units), on the low side, within the range that was stated.
By their numbers in this assay, from the lowest: compound 2; then compound 3; then compound 1.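

In this assay, this position on the shared core can now be compared across three groups: hydrogen, chloro and amino. Amino gives a 20-fold higher number from compound 2 to compound 3 (1.30 log units; beyond the scatter) when it replaces chloro, but still gives a 4.9-fold lower number from compound 1 to compound 3 (0.69 log units; beyond the scatter) when it replaces hydrogen, so a lower number at this place does not depend on chloro alone, although chloro gives by far the lower number of the two. No evidence is available to explain this order among the three groups. Going by these compounds, whether bromo, fluoro or methyl at this place would come closer to chloro or to amino remains open. Also open, on these data alone, is whether a substituted amine such as dimethylamino would keep the gain that amino shows over hydrogen.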